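Ring-nitrogen aryl swap: compound 3 to compound 4

The compounds below may be only part of what the source reports. "The series", "measured", "known", "first", "only" and "open" are said of these compounds alone.

Compound 1 `N=C1S/C(=C\c2ccc(OCc3ccccc3)cc2)C(=O)N1c1ccc(F)cc1` gives 10.5% in an ADME assay on RAW264.7 cells (Mus musculus) for cytotoxicity, read by MTT assay, with a stated time of 48 h, tested at 50 uM; a higher number here means more inhibition at the concentration tested (going by the name of the read-out), a lower number less inhibition. Compound 2 `N=C1S/C(=C\c2ccc(OCc3ccccc3)cc2)C(=O)N1c1ccccc1` gives 37.9% in this assay, and compound 3 `Cc1ccc(N2C(=N)S/C(=C\c3ccc(OCc4ccccc4)cc3)C2=O)c(C)c1` gives 36.8%. Compound 3 stands second highest of the three numbers; it sits within the scatter of compound 2, and a number 26.3 percentage points higher from compound 1 to compound 3 (beyond the scatter) lies beyond the scatter. Compound 4 `Cc1ccc(C)c(N2C(=N)S/C(=C\c3ccc(OCc4ccccc4)cc3)C2=O)c1` differs from compound 3 by 2,5-dimethylphenyl in place of 2,4-dimethylphenyl on an amide-type nitrogen in a ring. Going by the values given here, no measured step exchanges one dimethylphenyl for another; the nearest comparison is a number 1.1 percentage points lower from compound 2 to compound 3 (within the scatter), while the larger movements, a number 27.4 percentage points higher from compound 1 to compound 2 (beyond the scatter) and a number 26.3 percentage points higher from compound 1 to compound 3 (beyond the scatter), concern the removal of fluoro. A step of no size beyond the scatter is therefore expected, a number 0.8 percentage points lower from compound 3 to compound 4 (within the scatter). Compound 4 is estimated at 36%, within 22% to 50%.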

Compound 4, a percentage reported as inhibition, at one concentration (the size of the read-out at that concentration, not a potency): 45.8%
For compound 4 the middle estimate is 9.8 percentage points below the measured one; measured number inside the range.
By their numbers in this assay, from the lowest: compound 1; then compounds 3, 2 and 4 (each within the scatter of the next).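

In this assay, 2,5-dimethylphenyl in place of 2,4-dimethylphenyl on the amide-type nitrogen gives a number 9 percentage points higher from compound 3 to compound 4 (within the scatter) and so separates neither dimethylphenyl compound from the other. 2,5-Dimethylphenyl in place of phenyl gives a number 7.9 percentage points higher from compound 2 to compound 4 (within the scatter) while in place of 4-fluorophenyl it gives a number 35.3 percentage points higher from compound 1 to compound 4 (beyond the scatter), leaving compound 1 as the only one apart from the rest. No evidence on the origin of these numbers is available. From the compounds shown here alone, whether a chloro, methoxy or amino group on this aryl ring would group with compound 1 or with compound 2 remains open.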